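This account rests on a few compounds, and the source may have more. Where it says the series, first, only, none or still open, it means among the compounds named here.

Two diacylhydrazines sharing one core are in hand. Compound 1 `Cc1ccccc1C(=O)N(NC(=O)c1ccccc1)C(C)(C)C` and compound 2 `CC(C)(C)N(NC(=O)c1ccccc1F)C(=O)c1ccccc1Cl` were run in an assay on cells for agonist activity at ecdysone receptor (Bombyx mori), read by a luciferase reporter, with a stated time of 24 h; on this read-out lower numbers stand for an effect already at smaller amounts and higher numbers for an effect only at larger amounts of compound. Compound 1 gives 224 nM, while compound 2 gives 51.3 nM, the lower of the two numbers and beyond the scatter from compound 1. Compound 3 `CC(C)(C)N(NC(=O)c1ccccc1Br)C(=O)c1ccccc1Cl` is not yet measured; it differs from compound 2 by bromo in place of fluoro on an aromatic carbon. For the measured compounds named here, no step of this kind exists among the measured compounds, so the expected step of a 1.3-fold lower number from compound 2 to compound 3 (0.11 log units; within the scatter) is set near none beyond the scatter. For compound 3 the expected value in this assay is 40 nM, within 12 nM to 130 nM.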

Compound 3, half-maximal effective concentration: 316 nM
Compound 3: the middle estimate sits 7.9-fold (0.90 log units) below what was measured; the measured number lies above the stated range.
By their numbers in this assay, from the lowest: compound 2; then compounds 1 and 3 (each within the scatter of the next).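

In this assay, the aromatic carbon carrying the halogen is not indifferent to which halogen sits there: bromo in place of fluoro gives a 6.2-fold higher number from compound 2 to compound 3 (0.79 log units; beyond the scatter) in this single-place comparison. For the compounds shown here, this is the first step that isolates one position, and it involves no change in ring, hydrogen-bond donors, hydrogen-bond acceptors or net charge. Going by these compounds, whether chloro, methoxy or an amine on this carbon would sit nearer compound 2 or compound 3 remains open, as does whether the step would recur with another part of the molecule changed. Nothing available bears on the reason for this step.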